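The compounds below may be only part of what the source reports. "The series", "measured", "known", "first", "only" and "open" are said of these compounds alone.

Measured so far in an ADME assay on HMEC-1 cells (Homo sapiens) for cytotoxicity, read by MTT assay, with a stated time of 72 h; a lower number here means that less compound is tolerated, a higher number that more compound is tolerated:
compound 1, `Cc1c(CN2CCCC2)cc(-c2ccccc2)n1Nc1ccnc2cc(Cl)ccc12`, gives 12900 nM
compound 2, `Cc1c(CN2CCCC2)cc(-c2ccc(Cl)cc2)n1Nc1ccnc2cc(Cl)ccc12`, gives 7180 nM
compound 3, `Cc1c(CN2CCCC2)cc(-c2ccc(F)cc2)n1Nc1ccnc2cc(Cl)ccc12`, gives 10100 nM

Compound 3 stands second highest of these three numbers. Its nearest neighbour is compound 1, with a 1.3-fold lower number from compound 1 to compound 3 (0.11 log units; within the scatter), and its furthest is compound 2, with a 1.4-fold higher number from compound 2 to compound 3 (0.15 log units; within the scatter), so all three sit within the scatter of one another.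

The unmeasured compound 4, `Cc1c(CN2CCCC2)cc(-c2ccc(C(F)(F)F)cc2)n1Nc1ccnc2cc(Cl)ccc12`, differs from compound 3 by trifluoromethyl in place of fluoro on an aromatic carbon. Within the data shown here, the steps that bear on this change are the three substitutions on the same six-membered aromatic ring of carbon only: a 1.8-fold lower number from compound 1 to compound 2 (0.25 log units; within the scatter), a 1.3-fold lower number from compound 1 to compound 3 (0.11 log units; within the scatter) and a 1.4-fold higher number from compound 2 to compound 3 (0.15 log units; within the scatter). None of them moved the number beyond the scatter, and the trifluoromethyl group enters a place where chloro and fluoro both left the number essentially unchanged. A step in this assay is therefore expected to be small, if anything slightly downward, and is not expected to exceed the scatter. Compound 4 is expected to give 8000 nM, in a range from 3500 nM to 18000 nM. This expectation amounts to a 1.3-fold lower number from compound 3 to compound 4 (0.10 log units; within the scatter).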

Compound 4, half-maximal cytotoxic concentration: 4700 nM
Beside the measured number, compound 4's estimate is 1.7-fold (0.23 log units) above it; low and high end bracket the measured number.
By their numbers in this assay, from the lowest: compounds 4, 2, 3 and 1 (each within the scatter of the next, the first and the last beyond it).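

Among these compounds, at this aromatic carbon, a change now moves the number beyond the scatter in this assay: trifluoromethyl in place of fluoro gives a 2.1-fold lower number from compound 3 to compound 4 (0.33 log units; beyond the scatter), and trifluoromethyl in place of hydrogen gives a 2.7-fold lower number from compound 1 to compound 4 (0.44 log units; beyond the scatter), whereas no step among the earlier compounds went beyond it. Trifluoromethyl in place of chloro gives only a 1.5-fold lower number from compound 2 to compound 4 (0.18 log units; within the scatter), so compound 2 and compound 4 cannot be separated here, and the position responds modestly rather than sharply. Nothing available explains why the number shifts with this group.

On these data alone, it remains open whether a nitrile, a methoxy group or an amine at this carbon would lower the number as well or leave it within the scatter. Also open, as far as these compounds go, is whether the step from fluoro to trifluoromethyl would persist if another part of the shared core were changed.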